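Benzhydryl to benzyl ester on the exocyclic chain

The compounds below may be only part of what the source reports. "The series", "measured", "known", "first", "only" and "open" are said of these compounds alone.

Compound 1 `CC1(C)[C@H](C(=O)OC(c2ccccc2)c2ccccc2)N2C(=O)/C(=C/C(=O)c3ccccc3)[C@H]2S1(=O)=O`, compound 2 `CCOC(=O)/C=C1/C(=O)N2[C@@H]1SC(C)(C)[C@@H]2C(=O)OC(c1ccccc1)c1ccccc1` and compound 3 `CC1(C)S[C@@H]2/C(=C\C(=O)OC(c3ccccc3)c3ccccc3)C(=O)N2[C@H]1C(=O)OC(c1ccccc1)c1ccccc1` share one core. In a functional assay on NCI-H1299 cells (Homo sapiens) for cytotoxicity, read by MTT assay, with a stated time of 48 h (on this read-out higher numbers stand for weaker inhibition and lower numbers for stronger inhibition), compound 1 gives 50100 nM, compound 2 gives 15000 nM and compound 3 gives 22400 nM. Compound 3 stands second highest of the three numbers: compound 2 is nearest, the gap within the scatter, while compound 1 is furthest, the gap beyond it. Compound 4 `CC1(C)S[C@@H]2/C(=C\C(=O)OCc3ccccc3)C(=O)N2[C@H]1C(=O)OC(c1ccccc1)c1ccccc1` differs from compound 3 by hydrogen in place of phenyl on a saturated chain carbon bound to an aromatic carbon and an oxygen next to a carbonyl group. Among the compounds with values here, no measured pair shows this change, so the step in this assay is expected to be small, most likely none beyond the scatter, since compound 2 with its smaller ester gives 15000 nM. Compound 4 is therefore estimated at 18000 nM, within 7000 nM to 50000 nM. The expected step is a 1.2-fold lower number from compound 3 to compound 4 (0.09 log units; within the scatter).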

Compound 4, half-maximal inhibitory concentration: 9400 nM
Estimate against measurement, compound 4: 1.9-fold (0.28 log units) above; the measured number falls inside the stated range.
By their numbers in this assay, from the lowest: compounds 4, 2 and 3 (each within the scatter of the next, the first and the last beyond it); then compound 1.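

In this assay, hydrogen in place of phenyl on this ester carbon gives a 2.4-fold lower number from compound 3 to compound 4 (0.38 log units; beyond the scatter), so the second phenyl is not required for this cytotoxicity. Phenyl in place of methyl at the same carbon gives a 1.6-fold lower number from compound 2 to compound 4 (0.20 log units; within the scatter), which leaves the benzyl and ethyl esters indistinguishable here. Nothing measured on these compounds accounts for either step. Still open, as far as these compounds go, is how a carboxylic acid in place of this ester would read, and whether a longer chain before the phenyl would shift the number beyond the scatter.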